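This account rests on a few compounds, and the source may have more. Where it says the series, first, only, none or still open, it means among the compounds named here.

Measured so far in an assay on isolated protein for binding affinity to secreted frizzled-related protein 1 (Homo sapiens), read by fluorescence; a lower number here means a stronger inhibitor, a higher number a weaker inhibitor:

Compound 1 `O=C(CN1CCNCC1)N1CCC(NS(=O)(=O)c2cc(S(=O)(=O)c3ccccc3)ccc2C(F)(F)F)CC1` gives 140 nM.
Compound 2 `O=C(Cn1ccnc1)N1CCC(NS(=O)(=O)c2cc(S(=O)(=O)c3ccccc3)ccc2C(F)(F)F)CC1` gives 30 nM.
Compound 3 `CC(C)(C)OC(=O)N1CCC[C@@H]1C(=O)N1CCC(NS(=O)(=O)c2cc(S(=O)(=O)c3ccccc3)ccc2C(F)(F)F)CC1` gives 120 nM.

Compound 3 holds the second highest of the three numbers. Its nearest neighbour is compound 1, with a 1.2-fold lower number from compound 1 to compound 3 (0.07 log units; within the scatter) separating them, a gap within the scatter, so no order between compound 1 and compound 3 can be claimed. Within the data shown here, compound 2 stands apart from both: a 4.7-fold lower number from compound 1 to compound 2 (0.67 log units; beyond the scatter) and a 4.0-fold higher number from compound 2 to compound 3 (0.60 log units; beyond the scatter) are the only steps beyond the scatter in the set.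

Compound 4 `CC(C)C(=O)N1CCC[C@H]1C(=O)N1CCC(NS(=O)(=O)c2cc(S(=O)(=O)c3ccccc3)ccc2C(F)(F)F)CC1` differs from compound 3 at the carbonyl carbon attached to the ring nitrogen:

1-(isopropylcarbonyl)pyrrolidin-2-yl in place of 1-(tert-butoxycarbonyl)pyrrolidin-2-yl on a carbonyl carbon

Among the measured compounds shown here, none of the measured steps touches this site in the same way. The steps from compound 1 and compound 2 to compound 3 each replace the whole group on the carbonyl carbon, whereas the change to compound 4 keeps the pyrrolidin-2-yl ring and its stereocentre and alters only the cap on the ring nitrogen. For the measured compounds named here, there is therefore no measured step that bears directly on the change, and no direction can be read from the set.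

The expectation is a step that stays within the scatter, with compound 3 as the anchor: no change at the digits printed from compound 3 to compound 4 (within the scatter). Compound 4 is estimated at 120 nM, with a range from 50 nM to 300 nM.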

Compound 4, half-maximal inhibitory concentration: 40 nM
Compound 4: middle estimate off by 3.0-fold (0.48 log units), on the high side; measured number below the stated range.
By their numbers in this assay, from the lowest: compounds 2 and 4 (each within the scatter of the next); then compounds 3 and 1 (each within the scatter of the next).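

Among these compounds, the cap on the ring nitrogen of the pyrrolidin-2-yl group matters in this assay: with a 3.0-fold lower number from compound 3 to compound 4 (0.48 log units; beyond the scatter), isopropylcarbonyl in place of tert-butoxycarbonyl gives a step beyond the scatter, whereas the earlier steps at this site replaced the whole group on the carbonyl carbon. The 1-(isopropylcarbonyl)pyrrolidin-2-yl group also shows that (1H-imidazol-1-yl)methyl is not alone in giving a number of this size, with a 1.3-fold higher number from compound 2 to compound 4 (0.12 log units; within the scatter) lying within the scatter, while a 3.5-fold lower number from compound 1 to compound 4 (0.54 log units; beyond the scatter) sets it clear of (piperazin-1-yl)methyl. The two structures are also drawn with opposite configuration at the stereocentre, so this step joins two changes, and nothing at hand explains it.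

On these data alone, whether the cap or the configuration carries the step stays open. Also open, as far as these compounds go, is how a free amine at the ring nitrogen, an acetyl cap or a longer acyl chain would stand against the isopropylcarbonyl group.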